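Removing an Isopropyl Group: Expected Effect on Receptor Binding

A few compounds are considered here, and "the series" means these few. Any claim that something is new, unique, unknown or untested is made for them only; others in the source may bear on it.

Of the compounds shown here, three built on one shared core have been measured. Compound 1 `CN1CCN(c2nc(N)nc(COc3ccccc3)n2)CC1` gives 9530 nM in an assay on HEK293 cells for displacement of a labelled ligand from 5-hydroxytryptamine receptor 7 (Homo sapiens), read by radioligand binding, with a stated time of 1 h; on this read-out lower numbers stand for stronger inhibition and higher numbers for weaker inhibition. Compound 2 `CN1CCN(c2nc(N)nc(COc3cccc(Cl)c3)n2)CC1` gives 5820 nM in this assay, and the step from compound 1 to compound 2 a 1.6-fold lower number from compound 1 to compound 2 (0.21 log units; within the scatter) comes from a chloro in place of hydrogen on an aromatic carbon. Compound 3 `Cc1ccc(C(C)C)c(OCc2nc(N)nc(N3CCN(C)CC3)n2)c1` gives 12000 nM in this assay, the highest number of the three; compound 1 sits within the scatter of it, while compound 2 lies beyond the scatter.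

Compound 4 `Cc1cccc(OCc2nc(N)nc(N3CCN(C)CC3)n2)c1` has not yet been measured. It differs from compound 3 by hydrogen in place of isopropyl on an aromatic carbon. Among the measured compounds shown here, no measured step removes an isopropyl group, so none bears directly on this change; the only known step, from compound 1 to compound 2, is within the scatter and concerns a different group. Compound 4 also resembles compound 1 with one added methyl group. The number expected for compound 4 in this assay is therefore close to that of compound 3, giving a 1.3-fold lower number from compound 3 to compound 4 (0.10 log units; within the scatter) as the estimated step, with no change expected beyond the scatter. The estimate for compound 4 is 9500 nM, with a range from 4000 nM to 22000 nM.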

Compound 4, inhibition constant: 10700 nM
The estimate for compound 4 lay 1.1-fold (0.05 log units) below the measured number; the measured number falls inside the stated range.
By their numbers in this assay, from the lowest: compounds 2, 1, 4 and 3 (each within the scatter of the next, the first and the last beyond it).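

Hydrogen in place of isopropyl, on the aromatic carbon para to a methyl group, gives a 1.1-fold lower number from compound 3 to compound 4 (0.05 log units; within the scatter) in this assay and so shows that the two groups cannot be told apart at this position. The methyl group on the ring also leaves the number within the scatter: a 1.1-fold higher number from compound 1 to compound 4 (0.05 log units; within the scatter) with methyl in place of hydrogen, and a 1.8-fold higher number from compound 2 to compound 4 (0.26 log units; within the scatter) with methyl in place of chloro. Nothing available accounts for why these steps are so small.

Going by these compounds, whether an amine, a carboxylic acid or a longer chain at this position would move the number beyond the scatter remains open. Also open, on these data alone, is whether a change to the shared core would shift the number more than these changes on the aromatic ring do.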